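This account rests on a few compounds, and the source may have more. Where it says the series, first, only, none or still open, it means among the compounds named here.

Among the measured compounds shown here, compound 1 `COc1cc(C(C)=O)ccc1OCCCN1CCC(C(c2ccc(F)cc2)c2ccc(F)cc2)CC1` gives 1.59 nM in a functional assay (aorta) with Oryctolagus cuniculus as the target (on this read-out lower numbers stand for tighter binding and higher numbers for weaker binding), the lower of the two numbers known; compound 2 `COc1cc(C(C)=O)ccc1OCCCN1CCC(Cc2ccc(F)cc2)CC1` gives 20 nM, and the step of a 13-fold higher number from compound 1 to compound 2 (1.10 log units; beyond the scatter) concerns the other end of the molecule. Compound 3 `CN(CCCN1CCC(C(c2ccc(F)cc2)c2ccc(F)cc2)CC1)c1ccccc1` differs from compound 1 at the chain end: methyl(phenyl)amino in place of 4-acetyl-2-methoxyphenoxy on a saturated chain carbon, three bonds along the chain from an amine nitrogen in a ring. For the measured compounds named here, no measured step touches this place, so the measured data give no direct guide; a moderate weakening is expected, a 3.8-fold higher number from compound 1 to compound 3 (0.58 log units; beyond the scatter), because the removed group in compound 1 goes together with 1.59 nM. Compound 3 is therefore estimated at 6 nM, within 1.5 nM to 30 nM.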

Compound 3, dissociation constant: 2 nM
Estimate against measurement, compound 3: 3.0-fold (0.48 log units) above; the range from low to high includes it.
By their numbers in this assay, from the lowest: compounds 1 and 3 (each within the scatter of the next); then compound 2.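

In this assay, methyl(phenyl)amino in place of 4-acetyl-2-methoxyphenoxy gives a 1.3-fold higher number from compound 1 to compound 3 (0.10 log units; within the scatter), so this pair does not separate the two end groups. The change takes the end group from 12 heavy atoms to 8 and swaps three oxygen atoms for one nitrogen, yet the read-out stays within the scatter. Nothing available bears on why the two groups read alike. From the compounds shown here alone, both end groups carry an aromatic ring, so whether one is needed stays open; a dimethylamino end would test that. Going by these compounds, how a longer chain would read is also open.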